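Amino-substituent variation on the thiadiazole series: ethylamino analogue

This account rests on a few compounds, and the source may have more. Where it says the series, first, only, none or still open, it means among the compounds named here.

Compound 1 `COCCNc1nnc(SCC(=O)N(Cc2cccc([N+](=O)[O-])c2)c2ccc(F)cc2)s1` and compound 2 `CC(C)Nc1nnc(SCC(=O)N(Cc2cccc([N+](=O)[O-])c2)c2ccc(F)cc2)s1` share a core and differ only on the nitrogen on the aromatic ring. In an assay on isolated protein for inhibition of Amine oxidase [flavin-containing] A (Homo sapiens), read by fluorescence and Amplex Red, with a stated time of 30 min, tested at 1 uM (a lower number here means a weaker effect, a higher number a stronger effect of the compound at the concentration tested), compound 1 gives 72.7%, and compound 2 gives 46%; the change a number 26.7 percentage points lower from compound 1 to compound 2 (beyond the scatter) is isopropyl in place of 2-methoxyethyl. Compound 2 thus stands as the lowest of the two numbers, with compound 1 the nearest and higher.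

Compound 3 `CCNc1nnc(SCC(=O)N(Cc2cccc([N+](=O)[O-])c2)c2ccc(F)cc2)s1` follows from compound 2 by the change (hydrogen in place of methyl on a saturated chain carbon bound to a nitrogen on an aromatic ring and a saturated chain carbon), read one bond further out as isopropyl to ethyl. No measured step covers this change; the only step shown swaps a chain carrying an oxygen for isopropyl, which is a different kind of difference, so it gives little direct guidance. The step of a number 4 percentage points higher from compound 2 to compound 3 (within the scatter) is therefore expected to be small, with no clear direction beyond the scatter. Compound 3 is estimated at 50% in this assay, within a range of 30% to 70%.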

Compound 3, a percentage reported as inhibition, at one concentration (the size of the read-out at that concentration, not a potency): 61.9%
Compound 3: middle estimate off by 11.9 percentage points, on the low side, within the range that was stated.
By their numbers in this assay, from the lowest: compound 2; then compound 3; then compound 1.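

In this assay, isopropylamino to ethylamino gives a number 15.9 percentage points higher from compound 2 to compound 3 (beyond the scatter), so the read-out at this position responds to the loss of a single methyl, and not only to the larger swap seen earlier. Hydrogen in place of methoxy on the chain gives a number 10.8 percentage points lower from compound 1 to compound 3 (beyond the scatter), so ethyl does not match 2-methoxyethyl, and the three substituents stand apart beyond the scatter, with ethyl in the middle. No available evidence bears on the reason for these differences.

Open, going by these compounds, is whether the trend from isopropyl to ethyl carries on to a methylamino group or an unsubstituted amine. Also open, on these data alone, is whether the edge of compound 1 belongs to the ether oxygen or to chain length, which a comparison with an n-propyl or n-butyl chain would help to separate.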